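Thienyl series: substituent at the position by the ring sulfur

The source may report more compounds than this note shows. Statements on the series, on what has been measured and on what is new or still open speak of the compounds shown alone.

Compound 1 `CC(C)(C)Cc1csc(N)c1C(=O)c1ccc(Cl)cc1` gives 5% in an assay on CHO cells for displacement of a labelled ligand from adenosine receptor A3 (Homo sapiens), read by scintillation counting, tested at 10 uM; a lower number here means less inhibition, a higher number more inhibition at the concentration tested (going by the name of the read-out). Compound 2 `COc1ccc(-c2sc(N)c(C(=O)c3ccc(Cl)cc3)c2C)cc1` gives 1% and compound 3 `CC(C)(C)Cc1c(-c2ccoc2)sc(N)c1C(=O)c1ccc(Cl)cc1` gives 1%; all three numbers lie within the scatter of one another, so no ordering among them can be read. Within the data shown here, the one single-point step so far, a number 4 percentage points lower from compound 1 to compound 3 (within the scatter), places an aromatic ring at the same position that compound 4 `CC(C)(C)Cc1c(/C=C/c2ccc(Cl)cc2)sc(N)c1C(=O)c1ccc(Cl)cc1` alters: 2-(4-chlorophenyl)ethenyl in place of hydrogen on an aromatic carbon. That step carried no signal beyond the scatter, and nothing else in the set speaks for a shift, so compound 4 is expected to stay close to compound 1 in this assay, with a number 1 percentage points lower from compound 1 to compound 4 (within the scatter) as the expected step. The estimate for compound 4 is 4%, within 0% to 15%.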

Compound 4, a percentage reported as inhibition, at one concentration (the size of the read-out at that concentration, not a potency): 11%
Compound 4: middle estimate off by 7 percentage points, on the low side, and the stated range covers the measured number.
By their numbers in this assay, from the lowest: compounds 2, 3, 1 and 4 (each within the scatter of the next).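

At the position next to the ring sulfur, a 2-(4-chlorophenyl)ethenyl group of 9 heavy atoms leaves the number within the scatter of both hydrogen (a number 6 percentage points higher from compound 1 to compound 4 (within the scatter)) and furan-3-yl (a number 10 percentage points higher from compound 3 to compound 4 (within the scatter)) in this assay. Among these compounds, the earlier step covered only a single ring placed directly on the core; this one shows the same outcome with a double bond between the core and a chlorine-bearing six-membered ring. No measurement given here bears on the result.

Still open, from the compounds shown here alone, is whether an amine, a carboxylic acid or a saturated alkyl chain at this position would give a step beyond the scatter. Any step beyond the scatter at this position also remains to be seen.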